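Chain amines on a shared core: acid dissociation

The source may hold more compounds than are shown below. What is called first, only, known or untested is meant among the compounds shown, and "the series" means these compounds.

Compound 1 `Cc1csc2cc([C@H](C)Nc3ncnc(N)c3C#N)c(-c3cccc(CN4CCC(N(C)CC(C)C)CC4)c3)c(=O)n12`: 6.8
Compound 2 `Cc1csc2cc([C@H](C)Nc3ncnc(N)c3C#N)c(-c3cccc(CN(C)CCCCN(C)Cc4ccccc4)c3)c(=O)n12`: 7

In a physicochemical assay for acid dissociation, compound 2 gives 7 and compound 1 gives 6.8; the two values lie within the scatter of each other, so no order between them can be read. Compound 3 `Cc1csc2cc([C@H](C)Nc3ncnc(N)c3C#N)c(-c3cccc(CN(C)CCCN4C[C@@H](C)O[C@@H](C)C4)c3)c(=O)n12` differs from compound 2 by 2,6-dimethylmorpholin-4-yl in place of (benzyl(methyl)amino)methyl on a saturated chain carbon, three bonds along the chain from an amine nitrogen. Going by the values given here, no measured pair in this set tracks such a change, so the step from compound 2 to compound 3 is expected to stay within the scatter, with no clear direction. Compound 3 is therefore estimated at 7, between 6.4 and 7.6, a step of no change at the digits printed from compound 2 to compound 3 (within the scatter).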

Compound 3, acid dissociation constant: 5.7
Compound 3: middle estimate off by 1.30 log units, on the high side, and the stated range ends above it.
By their numbers in this assay, from the lowest: compound 3; then compounds 1 and 2 (each within the scatter of the next).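

In this assay, putting 2,6-dimethylmorpholin-4-yl in place of (benzyl(methyl)amino)methyl on a saturated chain carbon, three bonds along the chain from an amine nitrogen, gives a number 1.30 log units lower from compound 2 to compound 3 (beyond the scatter). Going by these compounds alone, the earlier compounds offered no step at all, so this is the first sign that the read-out answers to a change at this position. Nothing at hand accounts for the size of this step. The compounds shown do not separate the part played by the ring oxygen from that of the lost benzyl group. A piperidine or an unsubstituted morpholine at this place would bear on that question.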